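The source may report more compounds than this note shows. Statements on the series, on what has been measured and on what is new or still open speak of the compounds shown alone.

Measured so far in an assay on isolated protein for displacement of a labelled ligand from secreted frizzled-related protein 1 (Homo sapiens), read by fluorescence polarization, with a stated time of 30 min; on this read-out higher numbers stand for weaker inhibition and lower numbers for stronger inhibition:
compound 1 `O=C(c1ccccc1)N1CCC(NS(=O)(=O)c2cc(S(=O)(=O)c3ccccc3)ccc2C(F)(F)F)CC1` gives 70 nM;
compound 2 `O=C(c1ccc(Cl)nc1)N1CCC(NS(=O)(=O)c2cc(S(=O)(=O)c3ccccc3)ccc2C(F)(F)F)CC1` gives 110 nM.

Among the compounds with values here, compound 2 has the higher of the two numbers, and its only neighbour, compound 1, sits within the scatter: the step of a 1.6-fold higher number from compound 1 to compound 2 (0.20 log units; within the scatter) was small. Compound 3 `O=C(O)c1ccc(N2CCC(NS(=O)(=O)c3cc(S(=O)(=O)c4ccccc4)ccc3C(F)(F)F)CC2)cc1` carries a larger change: 4-carboxyphenyl in place of (6-chloropyridin-3-yl)carbonyl on an amine nitrogen in a ring. Within the data shown here, the single measured step, a 1.6-fold higher number from compound 1 to compound 2 (0.20 log units; within the scatter), only exchanged one aromatic ring for another on the carbonyl carbon, so no measured step speaks to removing the carbonyl or adding a carboxy group. Compound 3 is therefore estimated at 150 nM, with a range from 40 nM to 600 nM. For compound 3 this means an expected 1.4-fold higher number from compound 2 to compound 3 (0.13 log units; within the scatter), with wide uncertainty either way.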

Compound 3, half-maximal inhibitory concentration: 120 nM
Beside the measured number, compound 3's estimate is 1.3-fold (0.10 log units) above it, within the range that was stated.
By their numbers in this assay, from the lowest: compounds 1, 2 and 3 (each within the scatter of the next).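

Putting 4-carboxyphenyl on the amine nitrogen in a ring gives a 1.1-fold higher number from compound 2 to compound 3 (0.04 log units; within the scatter) when it replaces (6-chloropyridin-3-yl)carbonyl, and a 1.7-fold higher number from compound 1 to compound 3 (0.23 log units; within the scatter) when it replaces benzoyl. Earlier, only the ring on the carbonyl carbon had varied; now the carbonyl is gone and a carboxylic acid is present, yet this assay separates none of the three compounds. No other data here bear on why these numbers stay so close.

From the compounds shown here alone, the carbonyl and the carboxylic acid changed together, so their separate contributions remain unknown. A plain phenyl, or a methyl ester or an amine in place of the acid, would help to pull them apart.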